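Lengthening the Methoxy Group of Compound 3 to Propoxy

The source may hold more compounds than are shown below. What is called first, only, known or untested is meant among the compounds shown, and "the series" means these compounds.

Of the compounds shown here, three sharing one core have been measured in a functional assay on the whole organism with Canis familiaris (Canis lupus familiaris) as the target; a lower number here means that less compound is needed, a higher number that more compound is needed for the effect. Compound 1 `CSc1ccc(-c2nc3cc[nH]cc-3n2)cc1` gives 4 mg/kg, compound 2 `COc1ccc(-c2nc3cc[nH]cc-3n2)c(OC)c1` gives 0.3 mg/kg, and compound 3 `COc1cc(SC)ccc1-c1nc2cc[nH]cc-2n1` gives 0.2 mg/kg. Compound 3 therefore stands level with compound 2 at the low end of these numbers: methylsulfanyl in place of methoxy gives a 1.5-fold lower number from compound 2 to compound 3 (0.18 log units; within the scatter), which stays within the scatter. Compound 1 lies far from both. Methoxy in place of hydrogen gives a 20-fold lower number from compound 1 to compound 3 (1.30 log units; beyond the scatter), a large step.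

Compound 4 `CCCOc1cc(SC)ccc1-c1nc2cc[nH]cc-2n1` differs from compound 3 in one place, (ethyl in place of hydrogen on a saturated chain carbon bound to an oxygen on an aromatic ring), so that methoxy becomes propoxy. The step of a 20-fold lower number from compound 1 to compound 3 (1.30 log units; beyond the scatter) is the one that bears most directly on this change, as it concerns the same methoxy group. For the measured compounds named here, it shows only what introducing that group did, however, and no measured compound carries a longer chain there. The step of a 1.5-fold lower number from compound 2 to compound 3 (0.18 log units; within the scatter) concerns a different group and offers little guidance. Most of the low number of compound 3 is expected to survive, with a modest part given back. The expected step is a 2.5-fold higher number from compound 3 to compound 4 (0.40 log units; beyond the scatter), towards a higher number in this assay. The estimated value for compound 4 is 0.5 mg/kg, with an expected range from 0.1 mg/kg to 2.5 mg/kg.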

Compound 4, dose for half-maximal effect: 1.2 mg/kg
For compound 4 the middle estimate is 2.4-fold (0.38 log units) below the measured one; the measured number falls inside the stated range.
By their numbers in this assay, from the lowest: compounds 3 and 2 (each within the scatter of the next); then compound 4; then compound 1.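

In this assay, for the compounds shown here, the earlier compounds showed only that methoxy in place of hydrogen lowers the number, and compound 4 now shows that this place does not tolerate a longer chain without cost: methoxy to propoxy gives a 6.0-fold higher number from compound 3 to compound 4 (0.78 log units; beyond the scatter) in this whole-organism read-out. The benefit of an oxygen-linked chain at this place is nevertheless not confined to methoxy, as propoxy in place of hydrogen still gives a 3.3-fold lower number from compound 1 to compound 4 (0.52 log units; beyond the scatter) and so keeps part of the gain. Nothing available here accounts for the loss that comes with the ethyl extension, and the data give no mechanism for it.

The compounds shown leave open how the number changes with chain length between these two groups, and ethoxy would be the direct test of whether it rises gradually or only beyond a certain length. They also leave open whether the loss depends on length alone or on the form of the chain, a question that isopropoxy, cyclopropylmethoxy or a propoxy chain ending in a hydroxyl group or an amine could address.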